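Trading Benzyl for Methyl on Selenium in Compound 1

The compounds below may be only part of what the source reports. "The series", "measured", "known", "first", "only" and "open" are said of these compounds alone.

Compound 1 `O=C(/N=C(/NC(=O)c1cc(-c2ccccc2)nc2ccccc12)[Se]Cc1ccccc1)c1cc(-c2ccccc2)nc2ccccc12` holds the second highest of three numbers in a functional assay on MCF7 cells (Homo sapiens) for cytotoxicity, read by MTT assay, with a stated time of 72 h (on this read-out higher numbers stand for weaker inhibition of growth and lower numbers for stronger inhibition of growth), where compound 1 gives 8460 nM. Compound 2 `O=C(/N=C(/NC(=O)c1cccs1)[Se]Cc1ccccc1)c1cccs1` gives 72500 nM, a higher number beyond the scatter, and compound 3 `C[Se]/C(=N\C(=O)c1ccno1)NC(=O)c1ccno1` gives 0.09 nM, far lower and also beyond the scatter. Compound 4 `C[Se]/C(=N\C(=O)c1cc(-c2ccccc2)nc2ccccc12)NC(=O)c1cc(-c2ccccc2)nc2ccccc12` is not yet measured; it differs from compound 1 by hydrogen in place of phenyl on a saturated chain carbon bound to a selenium atom, which read one bond further out is benzyl to methyl. Going by the values given here, no measured pair isolates this change, and compound 3 differs from compound 1 elsewhere as well, so the direction is uncertain. The step from compound 1 to compound 4 is expected to be a 4.2-fold lower number from compound 1 to compound 4 (0.63 log units; beyond the scatter), leaning toward a lower number. Compound 4 is estimated at 2000 nM, within 100 nM to 20000 nM.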

Compound 4, concentration for 50% growth inhibition: 490 nM
The estimate for compound 4 lay 4.1-fold (0.61 log units) above the measured number; the range from low to high includes it.
By their numbers in this assay, from the lowest: compound 3; then compound 4; then compound 1; then compound 2.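

In this assay, going by these compounds alone, hydrogen in place of phenyl on a saturated chain carbon bound to a selenium atom gives a 17-fold lower number from compound 1 to compound 4 (1.24 log units; beyond the scatter), the first measured step that isolates this change. With the shared core held constant, the change from benzyl to methyl clearly strengthens inhibition of growth. No available evidence accounts for the size of this step. As far as these compounds go, whether ethyl, a longer chain or an amine-bearing chain in place of the methyl would keep this gain remains open. So does whether the same change would have a similar effect on the core of compound 2.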